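A few compounds are considered here, and "the series" means these few. Any claim that something is new, unique, unknown or untested is made for them only; others in the source may bear on it.

Compound 1 `CC(C)Cn1nnc(Cc2ccc(-c3ccccc3)cc2)n1` in an assay for inhibition of Fatty-acid amide hydrolase 1 (Rattus norvegicus) (a higher number here means a weaker inhibitor, a lower number a stronger inhibitor), gives > 50000 nM, which is a limit of the assay rather than a number.
Compound 2 `COC(=O)Cn1nnc(Cc2ccc(-c3ccccc3)cc2)n1` in this assay gives > 50000 nM, again a limit.
Compound 3 `CN(C)C(=O)Cn1nnc(CNC(=O)c2ccc(-c3ccccc3)cc2)n1` in this assay gives > 50000 nM, also a limit.

All three measured compounds therefore sit at the same point, namely (the limit of > 50000 nM in this assay, at which 3 of the 3 values shown sit). Compound 3 stands there too, with no number of its own, only the limit, and the two other values shown are limits as well. Within the data shown here, the single measured step that changes one place, from compound 1 to compound 2, is a step that the two limits leave unreadable from compound 1 to compound 2, so it gives no readable size.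

Compound 4 `CC(C)Cn1nnc(CNC(=O)c2ccc(-c3ccccc3)cc2)n1` differs from compound 3 by isopropyl in place of dimethylcarbamoyl on a saturated chain carbon bound to an aromatic nitrogen. Among the measured compounds shown here, the only measured step that touches the same place, on a saturated chain carbon bound to an aromatic nitrogen, is the unreadable one from compound 1 to compound 2. For the measured compounds named here, no measured step therefore tells how large a change to expect in this assay, nor in which direction. Since every compound shown sits at the limit, the most likely outcome for compound 4 is expected to be a limit again, with a step that the limit leaves unreadable from compound 3 to compound 4. Compound 4 is thus estimated at 60000 nM, with a range from 20000 nM to 200000 nM.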

Compound 4, half-maximal inhibitory concentration: > 50000 nM
Compound 4: a limit, no number; the forecaster's own chance of this, stated with the estimate: 85%; the middle value does not contradict the limit.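

Compound 3 and compound 4 both stand at a limit of this assay rather than at a number, so the change from dimethylcarbamoyl to isopropyl cannot be read as a step of any size. The compounds shown leave open which change, if any, would bring a measurable value, since all of them rest at one point: the limit of > 50000 nM in this assay, at which 4 of the 4 values shown sit.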